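A Methoxy Replaces Carboxy on the Shared Core

The source may report more compounds than this note shows. Statements on the series, on what has been measured and on what is new or still open speak of the compounds shown alone.

Compound 1 `Cc1c(COc2cccc(OCC3CCOCC3)c2)[nH]c2ccc(C(=O)O)cc2c1=O`: 400 nM
Compound 2 `CCCCCCCCCc1[nH]c2ccccc2c(=O)c1C`: 5.6 nM

In a functional assay on HUVEC cells (Homo sapiens) for inhibition, using NADPH, with a stated time of 2 h (on this read-out lower numbers stand for stronger inhibition and higher numbers for weaker inhibition), compound 1 has the higher of the two numbers at 400 nM, which marks weaker inhibition, and its gap to compound 2 at 5.6 nM lies beyond the scatter. Compound 3 `COc1ccc2[nH]c(COc3cccc(OCC4CCOCC4)c3)c(C)c(=O)c2c1` has methoxy in place of carboxy on an aromatic carbon. Going by the values given here, no measured pair of compounds shows this change, so the expectation is a judgement. The expected move is toward a lower number and beyond the scatter, an estimated 6.7-fold lower number from compound 1 to compound 3 (0.82 log units; beyond the scatter). The estimated value for compound 3 is 60 nM, within an expected range of 15 nM to 250 nM.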

Compound 3, half-maximal inhibitory concentration: > 10000 nM
Compound 3 gave a limit, no number (the forecaster's own chance of this, stated with the estimate: 2%); middle value at least 160-fold (2.22 log units) away from the limit.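

In this assay methoxy in place of carboxy on this aromatic carbon gives an at least 25-fold higher number from compound 1 to compound 3 (1.39 log units; beyond the scatter) and so moves the shared core toward much weaker inhibition, showing that this position does not tolerate the change. Compound 3 stands at > 10000 nM and that value is a limit of the assay, not a number. The size of the step is therefore only a bound: the limit of > 10000 nM in this assay, at which 1 of the 3 values shown sits.

On these data alone, how far compound 3 lies past its limit remains open. So does how an amide, a hydroxy group or a tetrazole on this aromatic carbon would read.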